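The compounds below may be only part of what the source reports. "The series", "measured", "known", "first", "only" and "open" are said of these compounds alone.

Notes on the series. The shared core of compound 1, `CCCCCN(CCCCC)C(=O)N1CCN(C(=O)N(c2ccccc2)c2ccccc2)[C@H](C(=O)O)C1`, carries a carboxy group on a saturated ring carbon; in an assay on CHO cells for binding affinity to Substance-P receptor (Homo sapiens) (on this read-out higher numbers stand for weaker inhibition and lower numbers for stronger inhibition), compound 1 gives 130 nM. Compound 2, `CCCCCN(CCCCC)C(=O)N1CCN(C(=O)N(c2ccccc2)c2ccccc2)[C@H](CO)C1`, has hydroxymethyl in place of carboxy there, and in this assay compound 2 gives 280 nM; the step reads a 2.2-fold higher number from compound 1 to compound 2 (0.33 log units; beyond the scatter). Compound 3, `CCCCCN(CCCCC)C(=O)N1CCN(C(=O)N(c2ccccc2)c2ccccc2)[C@H](C(=O)NCCN(C(C)C)C(C)C)C1`, carries the (2-(diisopropylamino)ethyl)carbamoyl group on the same ring carbon, and in this assay compound 3 gives 217 nM. The step from the acid is a 1.7-fold higher number from compound 1 to compound 3 (0.22 log units; within the scatter), and from the alcohol a 1.3-fold lower number from compound 2 to compound 3 (0.11 log units; within the scatter). Compound 3 therefore stands second highest of the three numbers, within the scatter of both neighbours, so no order among them can be read.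

Compound 4, `CCCCCN(CCCCC)C(=O)N1CCN(C(=O)N(c2ccccc2)c2ccccc2)[C@H](C(=O)NCCN(CC)CC)C1`, differs from compound 3 only in the terminal amine: diethylamino in place of diisopropylamino on a saturated chain carbon, two bonds along the chain from an amide-type nitrogen. Within the data shown here, no measured step alters this amine; the only steps that touch the side chain at all are those from compound 1 and compound 2 into compound 3, both within the scatter. A change confined to the outer amine, with the same count of donors and acceptors, gives no ground for a step beyond the scatter in this assay in either direction.

The estimate for compound 4 is 220 nM, with a range of 110 nM to 450 nM; the step this implies is expected as a 1.0-fold higher number from compound 3 to compound 4 (0.01 log units; within the scatter).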

Compound 4, half-maximal inhibitory concentration: 11 nM
Beside the measured number, compound 4's estimate is 20-fold (1.30 log units) above it; measured number outside the range, below it.
By their numbers in this assay, from the lowest: compound 4; then compounds 1, 3 and 2 (each within the scatter of the next, the first and the last beyond it).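

In this assay, the terminal amine of the side chain proves to be a sensitive place: diethylamino in place of diisopropylamino, on a saturated chain carbon, two bonds along the chain from an amide-type nitrogen, gives a 20-fold lower number from compound 3 to compound 4 (1.30 log units; beyond the scatter), although the hydrogen-bond donor and acceptor counts stay the same and neither group carries a net charge. The side chain on the ring carbon had shown no step beyond the scatter in compound 3, but with the diethylamino end it reads a 12-fold lower number from compound 1 to compound 4 (1.07 log units; beyond the scatter) and a 25-fold lower number from compound 2 to compound 4 (1.41 log units; beyond the scatter), so among these compounds the outcome of replacing the carboxy or hydroxymethyl group depends on the amine at the end of the chain. No measurement shown here accounts for the size of this step.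

The compounds shown leave open whether the low number persists with a dimethylamino or pyrrolidin-1-yl group at the chain end, or falls away as soon as the amine changes at all. As far as these compounds go, it is also open whether a propyl chain in place of the ethyl chain between the amide nitrogen and the diethylamino group keeps this result.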